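Swapping One Aromatic Group on a Carbonyl Carbon

A few compounds are considered here, and "the series" means these few. Any claim that something is new, unique, unknown or untested is made for them only; others in the source may bear on it.

Of the compounds shown here, three have so far been measured in an ADME assay on HEK293 cells (Homo sapiens) for cytotoxicity, read by MTT assay, with a stated time of 72 h (on this read-out higher numbers stand for weaker inhibition and lower numbers for stronger inhibition), and compound 3 (`COc1ccc2[nH]cc(CCCN3CCN(C(=O)CN4CCN(C(=O)c5ccc(C)cc5)CC4)CC3)c2c1`) gives 147000 nM there. That number lies within the scatter of both neighbours: compound 2 (`COc1ccc(C(=O)N2CCN(CC(=O)N3CCN(CCCc4c[nH]c5ccc(OC)cc45)CC3)CC2)cc1`) with 190000 nM and compound 1 (`O=C(CN1CCN(C(=O)c2cccc(Cl)c2)CC1)N1CCN(CCCc2c[nH]c3ccccc23)CC1`) with 99100 nM in the same test. Compound 3 therefore holds no clearly separate place among them.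

Compound 4 (`COc1ccc2[nH]cc(CCCN3CCN(C(=O)CN4CCN(C(=O)c5cccc(Cl)c5)CC4)CC3)c2c1`) differs from compound 3 in one place: 3-chlorophenyl in place of 4-methylphenyl on a carbonyl carbon which amounts to 3-chlorophenyl in place of 4-methylphenyl on a carbonyl carbon.

Within the data shown here, the only measured step on a single change is a 1.3-fold lower number from compound 2 to compound 3 (0.11 log units; within the scatter) with methyl in place of methoxy on an aromatic carbon. It is a different swap, but it stayed within the scatter. Compound 1 also carries 3-chlorophenyl, and its 99100 nM is within the scatter of compound 3 as well.

So no step beyond the scatter is expected in this assay and the estimated change is a 1.2-fold lower number from compound 3 to compound 4 (0.07 log units; within the scatter) at most a small one. For compound 4 the estimated value is 125000 nM with an expected range from 70000 nM to 220000 nM in this test.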

Compound 4, half-maximal inhibitory concentration: 143000 nM
The estimate for compound 4 lay 1.1-fold (0.06 log units) below the measured number; low and high end bracket the measured number.
By their numbers in this assay, from the lowest: compounds 1, 4, 3 and 2 (each within the scatter of the next).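

On the carbonyl carbon, the whole aromatic group can be exchanged without leaving the scatter in this assay: 3-chlorophenyl replaces 4-methylphenyl (with a 1.0-fold lower number from compound 3 to compound 4 (0.01 log units; within the scatter)) and also 4-methoxyphenyl (with a 1.3-fold lower number from compound 2 to compound 4 (0.12 log units; within the scatter)). The earlier compounds shown here showed only methyl in place of methoxy on an aromatic carbon, whereas these steps involve a different substituent, and a separate change on the core, methoxy in place of hydrogen on an aromatic carbon, also stays within the scatter (with a 1.4-fold higher number from compound 1 to compound 4 (0.16 log units; within the scatter)). No measurement here offers an explanation for these results.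

From the compounds shown here alone, whether an amine or a carboxylic acid on this phenyl ring would produce a step beyond the scatter remains open. So does the effect of replacing the phenyl ring on this carbonyl carbon with a longer carbon chain.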